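Notes on compound 3 and compound 4

The source may hold more compounds than are shown below. What is called first, only, known or untested is meant among the compounds shown, and "the series" means these compounds.

In an ADME assay on HEK293 cells (Homo sapiens) for cytotoxicity, read by resazurin assay, with a stated time of 72 h (on this read-out lower numbers stand for higher toxicity in this test and higher numbers for lower toxicity in this test), compound 1 `O=C(O)c1ccc(CCOc2c(F)ccc3nc(C(=O)NCC4CCCCC4)[nH]c(=O)c23)cc1` gives > 20000 nM, a limit of the assay and not a number. Compound 2 `O=C(O)c1ccc(CCOc2c(F)ccc3nc(C(=O)NCc4cccc(OCC5CC5)c4)[nH]c(=O)c23)cc1` gives > 20000 nM, again a limit. Compound 3 `CCc1cccc(CNC(=O)c2nc3ccc(F)c(OCCc4ccc(C(=O)O)cc4)c3c(=O)[nH]2)c1` gives > 20000 nM, also a limit. Compound 3 therefore stands at the limit of > 20000 nM in this assay, at which 3 of the 3 values shown sit.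

Compound 4 `CCc1ccccc1CNC(=O)c1nc2ccc(F)c(OCCc3ccc(C(=O)O)cc3)c2c(=O)[nH]1` has the same atoms as compound 3, joined differently: 2-ethylphenyl in place of 3-ethylphenyl on a saturated chain carbon bound to an amide-type nitrogen. The change places 2-ethylphenyl in place of 3-ethylphenyl on a saturated chain carbon bound to an amide-type nitrogen.

For the measured compounds named here, three measured steps bear on this change: a step that the two limits leave unreadable from compound 1 to compound 2, a step that the two limits leave unreadable from compound 1 to compound 3 and a step that the two limits leave unreadable from compound 2 to compound 3. None of them has a readable size, and none is this same change, so they offer only indirect guidance. The expectation rests on compound 1, compound 2 and compound 3 all sharing (the limit of > 20000 nM in this assay, at which 3 of the 3 values shown sit).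

No step beyond the scatter is expected, and no direction is favoured, so the estimated step is a number no higher from compound 3 to compound 4 (the limit leaves the size open). A further limit is the most likely report. For compound 4 the estimated value is 20000 nM, within an expected range of 10000 nM to 40000 nM.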

Compound 4, half-maximal cytotoxic concentration: > 20000 nM
Compound 4 ended at the assay's limit; the forecaster's own chance of this, stated with the estimate: 85%; the middle value lies on the limit itself.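

In this assay compound 4 gives > 20000 nM, a limit of the assay and not a number. For the compounds shown here, no step among compound 1, compound 2, compound 3 and compound 4 can be read. The compounds shown leave open how the exchanged groups compare in size of effect: the limit of > 20000 nM in this assay, at which 4 of the 4 values shown sit.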